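Replacing morpholin-4-yl with (3-methoxyphenyl)amino at the assay limit

The source may hold more compounds than are shown below. What is called first, only, known or untested is meant among the compounds shown, and "the series" means these compounds.

In a functional assay on HL-60 cells (Homo sapiens) for antiproliferative activity, read by MTT assay, with a stated time of 24 h (a higher number here means a weaker inhibitor, a lower number a stronger inhibitor), compound 1 (`CCCCc1oc2ccccc2c1C(=O)c1ccc(OCC(N)=O)cc1`) gives > 50000 nM as a limit of the assay, not a number. Compound 2 (`CCCCc1oc2ccccc2c1C(=O)c1ccc(OCC(=O)N2CCCCC2)cc1`) gives > 50000 nM as a limit too. Compound 3 (`CCCCc1oc2ccccc2c1C(=O)c1ccc(OCC(=O)N2CCOCC2)cc1`) gives > 50000 nM as a limit as well, so it has no exact place on the scale.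

The next compound is compound 4 (`CCCCc1oc2ccccc2c1C(=O)c1ccc(OCC(=O)Nc2cccc(OC)c2)cc1`). The structural difference is (3-methoxyphenyl)amino in place of morpholin-4-yl on a carbonyl carbon and it puts (3-methoxyphenyl)amino in place of morpholin-4-yl on a carbonyl carbon.

The measured changes at that same carbonyl carbon bear on this one: a step that the two limits leave unreadable from compound 1 to compound 2 and a step that the two limits leave unreadable from compound 1 to compound 3 and a step that the two limits leave unreadable from compound 2 to compound 3 and none of them has a size that can be carried over. The whole record is the limit of > 50000 nM in this assay, at which 3 of the 3 values shown sit, and it offers no number to build on.

Among the compounds with values here, none of the measured groups at this carbon holds an aromatic ring, so the expectation stays loose. Little or no step is expected in this assay and any movement would more likely be toward a stronger inhibitor. That expectation starts from compound 3 and its limit of > 50000 nM in the same assay. In numbers the expected change is an at least 1.2-fold lower number from compound 3 to compound 4 (0.09 log units; that floor lies within the scatter) and this is only an estimate. Compound 4 is expected at 40000 nM with an estimated range from 8000 nM to 100000 nM and it may well return only a limit again.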

Compound 4, half-maximal inhibitory concentration: > 50000 nM
Compound 4: a limit, no number; the forecaster's own chance of this, stated with the estimate: 60%; middle value at least 1.2-fold (0.09 log units) away from the limit.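

In this assay compound 4 gives > 50000 nM as a limit of the assay, not a number. Within the data shown here, no step from compound 1, compound 2 or compound 3 to compound 4 can be read, because all four compounds share one limit: the limit of > 50000 nM in this assay, at which 4 of the 4 values shown sit. As far as these compounds go, how far each compound lies beyond that limit, and whether any group on this carbonyl carbon gives a measurable value, stays open.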